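The source may report more compounds than this note shows. Statements on the series, on what has been measured and on what is new or still open speak of the compounds shown alone.

Three compounds share one core, carrying an imine that links to a six-membered aromatic ring of carbon only. Compound 1 `Cc1c(/N=C/c2ccc(N(C)C)cc2)c(=O)n(-c2ccccc2)n1C` bears a dimethylamino group on that ring, and in a functional assay on HCT-116 cells (Homo sapiens) for cytotoxicity, read by MTT assay, with a stated time of 72 h (a higher number here means a weaker inhibitor, a lower number a stronger inhibitor), compound 1 gives 832000000 nM. Compound 2 `Cc1c(/N=C/c2cccc(O)c2)c(=O)n(-c2ccccc2)n1C` gives 617000000 nM, and compound 3 `Cc1c(/N=C/c2cccc([N+](=O)[O-])c2)c(=O)n(-c2ccccc2)n1C` gives 363000000 nM. Compound 1 therefore has the highest number of the three, although its gap to compound 2 lies within the scatter and only its gap to compound 3 is beyond it. Within the data shown here, the one measured step between neighbours, a 1.7-fold lower number from compound 2 to compound 3 (0.23 log units; within the scatter), concerns a change on this same ring. Compound 4 `Cc1c(/N=C/c2ccc(Cl)cc2)c(=O)n(-c2ccccc2)n1C` differs from compound 1 by chloro in place of dimethylamino on an aromatic carbon. Among the measured compounds shown here, no measured step involves a dimethylamino or a chloro group, so that step is only a loose guide: changes on this ring have so far moved the number little, and compound 1 already stands highest.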

Compound 4, half-maximal inhibitory concentration: 589000000 nM
For compound 4 the middle estimate is 1.2-fold (0.07 log units) below the measured one, and the stated range covers the measured number.
By their numbers in this assay, from the lowest: compounds 3, 4, 2 and 1 (each within the scatter of the next, the first and the last beyond it).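

In this assay chloro in place of dimethylamino, on the aromatic carbon para to a large group, gives a 1.4-fold lower number from compound 1 to compound 4 (0.15 log units; within the scatter). Among these compounds, this is the first measured change at this position, and it shows that exchanging these two groups leaves the number within the scatter. The change to 4-chlorophenyl in place of 3-hydroxyphenyl gives a 1.0-fold lower number from compound 2 to compound 4 (0.02 log units; within the scatter), also within the scatter, and nothing available explains either result. From the compounds shown here alone, whether a carboxylic acid, a primary amine or a longer chain at this position would shift the number beyond the scatter remains open.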